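From Methyl to Chloro: Estimating Compound 4

A few compounds are considered here, and "the series" means these few. Any claim that something is new, unique, unknown or untested is made for them only; others in the source may bear on it.

Three related compounds have been tested so far for their ability to stop cancer cells from multiplying. In a functional assay on HeLa cells (Homo sapiens) for antiproliferative activity, read by MTT assay, with a stated time of 72 h (on this read-out higher numbers stand for weaker inhibition and lower numbers for stronger inhibition), compound 1 `CCn1cc(C(=O)O)c(=O)c2cc(F)c(N3CCN(C(=N)NS(=O)(=O)c4ccc(C(F)(F)F)cc4)CC3)cc21` gives 32 nM, compound 3 `CCn1cc(C(=O)O)c(=O)c2cc(F)c(N3CCN(C(=N)NS(=O)(=O)c4ccccc4)CC3)cc21` gives 32 nM and compound 2 `Cc1ccc(S(=O)(=O)NC(=N)N2CCN(c3cc4c(cc3F)c(=O)c(C(=O)O)cn4C3CC3)CC2)cc1` gives 32 nM. Compound 2 therefore stands level with the other two, and the data give no reason to rank any of them above another.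

The next compound to be tested, compound 4 `N=C(NS(=O)(=O)c1ccc(Cl)cc1)N1CCN(c2cc3c(cc2F)c(=O)c(C(=O)O)cn3C2CC2)CC1`, departs from compound 2 in one place, with chloro in place of methyl on an aromatic carbon. Within the data shown here, the single measured step that bears on this swaps hydrogen in for trifluoromethyl on an aromatic carbon, and it shows no change at the digits printed from compound 1 to compound 3 (within the scatter). Among the measured compounds shown here, that is a different exchange from the one in compound 4, and no compound measured so far carries chloro, so the evidence is thin. Even so, the only exchange measured on an aromatic carbon left the value unmoved, so no shift beyond the scatter is expected in this assay. The expected size of the change is no change at the digits printed from compound 2 to compound 4 (within the scatter). For compound 4 the estimated value is 32 nM, with an expected range from 15 nM to 70 nM.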

Compound 4, half-maximal inhibitory concentration: 32 nM
Compound 4: the middle estimate sits on the measured number at the digits printed; the range from low to high includes it.
By their numbers in this assay, from the lowest: compounds 1, 2, 3 and 4 (each within the scatter of the next).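

In this assay, putting chloro in place of methyl on this aromatic carbon, para to a large group, gives no change at the digits printed from compound 2 to compound 4 (within the scatter), so the change from 4-methylphenyl to 4-chlorophenyl has now been read directly rather than inferred from a different exchange. Alongside the earlier step of no change at the digits printed from compound 1 to compound 3 (within the scatter), this makes two exchanges on this ring, in two separate pairs of compounds, and neither moves the value beyond the scatter. The data shown offer no measurement that explains why the value holds steady across these exchanges.

The compounds shown leave open whether a group of a different kind on this carbon, such as an amine, a carboxylic acid or a longer chain, would shift the value beyond the scatter. Going by these compounds, it also remains open whether a change elsewhere in these molecules, away from this ring, would have a larger effect on the read-out than any exchange seen here.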